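The compounds below may be only part of what the source reports. "The series", "measured", "known", "first", "only" and "open" are said of these compounds alone.

Measured compounds:
- compound 1, `C=CC(C)(C)c1[nH]c2ccc(C[C@H]3OC(C)(C)OC3(C)C)cc2c1/C=C1\NC(=O)[C@H](C)NC1=O`, 88000 nM
- compound 2, `C=CC(C)(C)c1[nH]c2ccc(CC=C(C)C)cc2c1/C=C1\NC(=O)C(=O)NC1=O`, 102000 nM
- compound 3, `C=CC(C)(C)c1[nH]c2ccc(CC=C(C)C)c(CC=C(C)C)c2c1C[C@@H]1NC(=O)[C@H](C)NC1=O`, 623000 nM

All three were tested in a functional assay; on this read-out higher numbers stand for weaker inhibition and lower numbers for stronger inhibition. Compound 1 has the lowest number of the three, but its value and that of compound 2 lie within the usual scatter of such measurements, so no order between them can be claimed. Compound 3 stands clearly apart, its number being well beyond the scatter from compound 1, so compound 3 is the weaker inhibitor of that pair.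

The next compound, compound 4, `C=CC(C)(C)c1[nH]c2ccccc2c1/C=C1\NC(=O)[C@H](C)NC1=O`, has not yet been tested in this assay. It differs from compound 1 in one place: hydrogen in place of (2,2,5,5-tetramethyl-1,3-dioxolan-4-yl)methyl on an aromatic carbon. A substantial piece of compound 1 is thus lost, with only a hydrogen in its place.

Within the data shown here, no directly comparable pair of measured compounds shows what this kind of change does here. The change is expected to shift the number in this assay only modestly, if at all, perhaps toward weaker inhibition, a step from compound 1 to compound 4 of a 1.7-fold higher number from compound 1 to compound 4 (0.23 log units; within the scatter). Compound 4 is therefore estimated at 150000 nM, with a likely range from 50000 nM to 500000 nM.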

Compound 4, half-maximal inhibitory concentration: 103000 nM
For compound 4 the middle estimate is 1.5-fold (0.16 log units) above the measured one; the measured number falls inside the stated range.
By their numbers in this assay, from the lowest: compounds 1, 2 and 4 (each within the scatter of the next); then compound 3.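

In this assay, putting hydrogen in place of (2,2,5,5-tetramethyl-1,3-dioxolan-4-yl)methyl on this aromatic carbon gives a 1.2-fold higher number from compound 1 to compound 4 (0.07 log units; within the scatter). This is the first pair shown that differs in one place, and it indicates that on this core a group of 10 heavy atoms, with its ring and defined stereocentre, can be removed without a change that stands out from the scatter. Nothing available explains why the number holds steady.

Among these compounds, only this one group and hydrogen are compared at this position, so it remains open whether any other group there would move the number. An amine or a carboxylic acid on the same aromatic carbon could stay within the scatter or go beyond it, and this single pair cannot tell which.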